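A few compounds are considered here, and "the series" means these few. Any claim that something is new, unique, unknown or untested is made for them only; others in the source may bear on it.

Of the compounds shown here, three have so far been tested in a functional assay on the whole organism (strain Sprague-Dawley) for inhibition, with Rattus norvegicus as the target; a lower number here means that less compound is needed, a higher number that more compound is needed for the effect. Compound 1 `CCCCc1ccc2ncc(-c3nn[nH]n3)cc2c1` is the only one of them with a firm number: in this assay compound 1 gives 5 mg/kg. Compound 3 `COc1ccc2cc(C(=O)O)cnc2c1` did not reach the effect within the doses tried, so for compound 3 the assay records only a limit, > 25 mg/kg, which is a boundary of the measurement rather than a value (the limit of > 25 mg/kg in this assay, at which 1 of the 3 values shown sits). Among the compounds with values here, compound 2 `Cc1cccc2c(=O)c(-c3nn[nH]n3)c[nH]c12` stands in the same situation in this assay, where compound 2 shows only the limit > 5 mg/kg, again a boundary and not a number, shared by no other compound here but resembling the case of compound 3 (the limit of > 5 mg/kg in this assay, at which 1 of the 3 values shown sits). So compound 2 sits at one of the two limits among the three values, with no measured number of its own.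

Compound 4 `O=c1c(-c2nn[nH]n2)c[nH]c2c(Br)cccc12` has not yet been measured in this assay. It differs from compound 2 in one place: bromo in place of methyl on an aromatic carbon. Within the data shown here, no step between two measured compounds exists that would show how such a change acts here, and compound 2 itself offers only a limit as a starting point. The step from compound 2 to compound 4 is therefore expected to stay within the usual scatter, estimated as a step that the limit leaves unreadable from compound 2 to compound 4. Compound 4 is expected to need about 10 mg/kg, somewhere between 3 mg/kg and 30 mg/kg, and it may well return only a limit again.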

Compound 4, minimum effective dose: > 5 mg/kg
Compound 4: a limit, no number; the forecaster's own chance of this, stated with the estimate: 60%; the middle value does not contradict the limit.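

In this assay compound 2 and compound 4 both stand at a limit and not at a number, so no step can be read for bromo in place of methyl on an aromatic carbon. The compounds shown leave open what dose compound 2 or compound 4 would need for the effect, and whether this change alters that dose at all.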